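This account rests on a few compounds, and the source may have more. Where it says the series, first, only, none or still open, it means among the compounds named here.

Compound 1 (`CCCn1ccc2cc(C(=O)c3cc(OC)c(OC)c(OC)c3)ccc21`) gives 2100 nM
Compound 2 (`COc1cc(C(=O)c2ccc3c(ccn3CC(=O)O)c2)cc(OC)c1OC`) gives 476 nM

In a functional assay (Homo sapiens) for inhibition, with a stated time of 72 h (on this read-out higher numbers stand for weaker inhibition and lower numbers for stronger inhibition), compound 2 gives 476 nM and so holds the lower of the two numbers measured. Compound 3 (`COc1cc(C(=O)c2ccc3c(ccn3CCC(=O)O)c2)cc(OC)c1OC`) differs from it in one place, with carboxymethyl in place of carboxy on a saturated chain carbon bound to an aromatic nitrogen. Among the measured compounds shown here, only one measured step bears on this, a modest one: a 4.4-fold lower number from compound 1 to compound 2 (0.64 log units; beyond the scatter) with carboxy in place of ethyl at that place. Compound 3 still carries a carboxy group, so a smaller step is expected. In this assay the expected change (a 1.3-fold higher number from compound 2 to compound 3 (0.10 log units; within the scatter)) stays within the scatter. For compound 3 the estimated value is 600 nM (200 nM to 1800 nM).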

Compound 3, half-maximal inhibitory concentration: > 10000 nM
Compound 3: a limit, no number; the forecaster's own chance of this, stated with the estimate: 3%; middle value at least 16-fold (1.22 log units) from the limit.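

In this assay compound 3 gives no number, only a limit: the limit of > 10000 nM in this assay, at which 1 of the 3 values shown sits. Carboxymethyl in place of carboxy gives an at least 21-fold higher number from compound 2 to compound 3 (1.32 log units; beyond the scatter), so the gain seen earlier depends on how the acid sits on the chain and not just on its presence. Carboxy in place of methyl at the chain end gives an at least 4.7-fold higher number from compound 1 to compound 3 (0.67 log units; beyond the scatter), so at this place the same group can lower or raise the number.

Open, going by these compounds, is how an amide or a methyl ester on the shorter chain would compare with the acid. An amine on either chain also remains to be placed.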